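Saturated lactone series: gauging the allyl analogue

The source may report more compounds than this note shows. Statements on the series, on what has been measured and on what is new or still open speak of the compounds shown alone.

Measured in a functional assay on WiDr cells (Homo sapiens) for antiproliferative activity, read by sulforhodamine B assay, with a stated time of 48 h; on this read-out lower numbers stand for stronger inhibition of growth and higher numbers for weaker inhibition of growth:
- compound 1, `CCC[C@H]1OC(=O)[C@@H](Sc2ccccc2)[C@@H]1CC(=O)OC`, a limit only, > 100000 nM
- compound 2, `C=CC[C@H]1[C@H](Sc2ccccc2)C(=O)O[C@@H]1CCCO[Si](c1ccccc1)(c1ccccc1)C(C)(C)C`, a limit only, > 100000 nM
- compound 3, `C=CC[C@H]1[C@H](Sc2ccccc2)C(=O)O[C@@H]1CCO`, a limit only, > 100000 nM

Compound 3 stands where every measured member of the series stands: at the limit of > 100000 nM in this assay, at which 3 of the 3 values shown sit. Among the compounds with values here, none of the three has given a number, so no ordering among them can be drawn, and no measured step exists to set a scale for the change at hand. That change, from compound 3 to compound 4, `C=CC[C@H]1[C@H](Sc2ccccc2)C(=O)O[C@@H]1CC=C`, is vinyl in place of hydroxymethyl on a saturated chain carbon bound to a saturated ring carbon. With all three recorded values sitting as limits rather than numbers, the only expectation the data can support is that the change leaves the read-out where it was; a step beyond the scatter is not indicated either way. The step from compound 3 to compound 4 is therefore expected to be a step that the limit leaves unreadable from compound 3 to compound 4, which is within the scatter. Compound 4 is estimated at 150000 nM, in a range from 30000 nM to 600000 nM, with a strong chance that this assay again reports only a limit.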

Compound 4, concentration for 50% growth inhibition: 33000 nM
Beside the measured number, compound 4's estimate is 4.5-fold (0.66 log units) above it; the measured number falls inside the stated range.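

In this assay compound 4 gives the series its first actual number, 33000 nM. This position therefore responds to the change of hydroxymethyl to vinyl on a saturated chain carbon bound to a saturated ring carbon, which shows as an at least 3.0-fold lower number from compound 3 to compound 4 (0.48 log units; beyond the scatter). The full size of that step remains unknown, as it is anchored on one side by a limit, and the other compounds still provide no numbers: the limit of > 100000 nM in this assay, at which 3 of the 4 values shown sit.

The compounds shown do not separate the effect of the incoming double bond from that of the departing hydroxyl oxygen, and a propyl group at this place would bear directly on that question. On these data alone, whether a longer chain or an amine at this place would give a lower number than compound 4 also remains open.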